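Aryl piperazine variation: fluoro to methyl

A few compounds are considered here, and "the series" means these few. Any claim that something is new, unique, unknown or untested is made for them only; others in the source may bear on it.

The series shares one core carrying a primary amine and a substituted piperazine; compound 1 `COc1ccc(-c2cnc3nc(N)nc(N4CCN(C(=O)NCc5ccccc5)CC4)c3n2)cc1OC` bears a benzylcarbamoyl group on the piperazine nitrogen, compound 2 `COc1ccc(-c2cnc3nc(N)nc(N4CCN(c5ccc(F)cc5)CC4)c3n2)cc1OC` a 4-fluorophenyl in its place. In a functional assay on cells (T-cell, Homo sapiens) for inhibition (on this read-out higher numbers stand for weaker inhibition and lower numbers for stronger inhibition), compound 1 gives 18 nM and compound 2 gives 100 nM. Among the compounds with values here, the only step measured so far, a 5.6-fold higher number from compound 1 to compound 2 (0.74 log units; beyond the scatter), concerns the exchange of the whole substituent on the ring amine. Compound 2 thus stands with the highest number of the two, and its nearest neighbour, compound 1, lies a clear step lower.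

Compound 3 `COc1ccc(-c2cnc3nc(N)nc(N4CCN(c5ccc(C)cc5)CC4)c3n2)cc1OC` keeps the aryl piperazine of compound 2 and changes only the substituent on the aromatic ring: methyl in place of fluoro on an aromatic carbon. Within the data shown here, no measured pair alters a substituent on this aromatic ring, so the step between compound 1 and compound 2 does not bear on it directly; it only fixes the starting number. With nothing to suggest a direction, the expected step of no change at the digits printed from compound 2 to compound 3 (within the scatter) is none beyond the scatter. Compound 3 is therefore estimated at 100 nM in this assay, with a range of 40 nM to 250 nM.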

Compound 3, half-maximal inhibitory concentration: 300 nM
Estimate against measurement, compound 3: 3.0-fold (0.48 log units) below, and the stated range ends below it.
By their numbers in this assay, from the lowest: compound 1; then compound 2; then compound 3.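

In this assay the exchange of fluoro for methyl gives a 3.0-fold higher number from compound 2 to compound 3 (0.48 log units; beyond the scatter) and so shows that this aromatic carbon, para to a large group, is not a silent place: one heavy atom swapped for another moves the number beyond the scatter, towards weaker inhibition. Set against the benzylcarbamoyl group, 4-methylphenyl gives a 17-fold higher number from compound 1 to compound 3 (1.22 log units; beyond the scatter) and widens the distance that 4-fluorophenyl had already opened, so both aryl piperazines stand at higher numbers than compound 1, and compound 3 is the weakest of the three. The data at hand offer no explanation for the difference between fluoro and methyl at this place.

As far as these compounds go, two substituents at one place do not make a trend, so it remains open where hydrogen, chloro, methoxy, an amine or a carboxylic acid would fall relative to fluoro and methyl. From the compounds shown here alone, it also remains open whether the step from fluoro to methyl would have the same size and direction on the shared core with a different link between the piperazine and the aromatic ring.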